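The source may hold more compounds than are shown below. What is called first, only, known or untested is meant among the compounds shown, and "the series" means these compounds.

In a toxicity assay on THP-1 cells (Homo sapiens) for inhibition (on this read-out lower numbers stand for higher toxicity in this test and higher numbers for lower toxicity in this test), compound 2 `Cc1cccc(-c2cnc(NC(=O)c3ccc(F)cc3)n2C)c1` gives > 100000 nM as its result, which is a limit and not a number. In the same read-out, compound 1 `Cn1c(-c2ccccc2F)cnc1NC(=O)c1ccc(F)cc1` gives > 100000 nM and this too is only a limit. The evidence so far is therefore the limit of > 100000 nM in this assay, at which 2 of the 2 values shown sit, and nothing more. Within the data shown here, the one measured step is a step that the two limits leave unreadable from compound 1 to compound 2 and so offers no size to carry forward. Compound 3 `Cn1c(-c2cccc(C#N)c2)cnc1NC(=O)c1ccc(F)cc1` differs from compound 2 in one place, with cyano in place of methyl on an aromatic carbon. Compound 2 offers only its limit of > 100000 nM as a basis for the expectation. The estimated change is a number no higher from compound 2 to compound 3 (the limit leaves the size open) and no shift beyond the scatter is expected in this assay in either direction. Compound 3 is estimated at 100000 nM with an expected range of 40000 nM to 200000 nM and the assay may well report only a limit again.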

Compound 3, half-maximal cytotoxic concentration: > 100000 nM
Compound 3 was reported as a limit; the forecaster's own chance of this, stated with the estimate: 85%; the middle value lies on the limit itself.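

Compound 3 is reported only as a limit, as are compound 1 and compound 2, so no step among these three compounds can be read. Going by these compounds, how far apart the three truly lie in this assay stays open; none has an exact number.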